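The source may hold more compounds than are shown below. What is called first, only, known or untested is meant among the compounds shown, and "the series" means these compounds.

Measured so far in an in vivo ADME assay on the whole organism (plasma) for pharmacokinetics, with Rattus norvegicus as the target, at a dose of 50 mg/kg by the oral route; a lower number here means less compound in the circulation, a higher number more compound in the circulation at the dose given:
- compound 1 `Cc1cc(C)c(NC(=O)c2sccc2S(=O)(=O)Nc2onc(C)c2Cl)c(Cl)c1` gives 103000 nM
- compound 2 `CCCS(=O)(=O)c1cc(C)cc(C)c1NC(=O)c1sccc1S(=O)(=O)Nc1onc(C)c1Cl` gives 5450 nM
- compound 3 `Cc1cc(C)c(NC(=O)c2sccc2S(=O)(=O)Nc2onc(C)c2Cl)c(C(=O)C2CC2)c1` gives 108000 nM

Compound 3 and compound 1 stand together at the top of this small set, and the step of a 1.0-fold higher number from compound 1 to compound 3 (0.02 log units; within the scatter) shows no real difference between them. Compound 2 lies well under both, as the step of a 20-fold higher number from compound 2 to compound 3 (1.30 log units; beyond the scatter) makes clear.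

The next compound, compound 4 `Cc1cc(C)c(NC(=O)c2sccc2S(=O)(=O)Nc2onc(C)c2Cl)c(C(=O)c2ccccc2)c1`, has not yet been measured. It differs from compound 3 by one swap (phenyl in place of cyclopropyl on a carbonyl carbon), with phenyl in place of cyclopropyl on a carbonyl carbon, so cyclopropylcarbonyl becomes benzoyl.

Among the measured compounds shown here, no measured step makes this exact change, so the evidence is indirect. The carbonyl stays in place, and replacing chloro with cyclopropylcarbonyl gave the step of a 1.0-fold higher number from compound 1 to compound 3 (0.02 log units; within the scatter), which is within the scatter. The only large drop came with propylsulfonyl in compound 2, in the step of a 19-fold lower number from compound 1 to compound 2 (1.28 log units; beyond the scatter), and compound 4 has no such group. That drop still shows that a single swap can matter, so the range is left wider on the low side.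

In this assay the expected change is small, no more than the scatter, and slightly downward: a 1.4-fold lower number from compound 3 to compound 4 (0.16 log units; within the scatter).

The estimate for compound 4 is 75000 nM, with an expected range from 25000 nM to 150000 nM.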

Compound 4, maximal plasma concentration: 63100 nM
Beside the measured number, compound 4's estimate is 1.2-fold (0.08 log units) above it, within the range that was stated.
By their numbers in this assay, from the lowest: compound 2; then compounds 4, 1 and 3 (each within the scatter of the next).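

In this assay, phenyl in place of cyclopropyl on a carbonyl carbon gives a 1.7-fold lower number from compound 3 to compound 4 (0.23 log units; within the scatter) and so shows that an aromatic ring of carbon can replace a three-membered non-aromatic ring here without a change that stands out from the scatter. Benzoyl in place of chloro on an aromatic carbon gives a 1.6-fold lower number from compound 1 to compound 4 (0.21 log units; within the scatter) and thus joins cyclopropylcarbonyl as a second carbonyl group that stays level with chloro, whereas benzoyl in place of propylsulfonyl gives a 12-fold higher number from compound 2 to compound 4 (1.06 log units; beyond the scatter) and leaves compound 2 as the one compound apart from the other three. None of the data shown offers a reason for these results or for the gap to compound 2.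

Among the compounds shown here, compound 2 is the only compound with a sulfonyl group, so it remains open whether the sulfonyl or its propyl chain goes with the lower number, a question that methylsulfonyl could address. As far as these compounds go, it is also open how far the carbonyl carbon tolerates other groups, such as an amine, a carboxylic acid or a longer chain in place of phenyl.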